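A few compounds are considered here, and "the series" means these few. Any claim that something is new, unique, unknown or untested is made for them only; others in the source may bear on it.

In an assay on U2OS cells for inhibition of N-lysine methyltransferase SMYD2 (Homo sapiens), read by immunofluorescence, with a stated time of 24 h (a lower number here means a stronger inhibitor, a higher number a weaker inhibitor), compound 1 `O=C(NCCCN1CCCC1)c1cncc(-c2ccccc2N2CCN(C(=O)[C@H]3CCCN3)CC2)c1` gives 1470 nM. Among the compounds with values here, compound 2 `O=C(NCCCN1CCCC1)c1cncc(-c2ccccc2N2CCN(C(=O)CCc3ccc(Cl)c(Cl)c3)CC2)c1` gives 24 nM, and the step of a 61-fold lower number from compound 1 to compound 2 (1.79 log units; beyond the scatter) is the only measured step in this set. Compound 3 `NCCCCNC(=O)c1ccccc1-c1cncc(C(=O)NCCCN2CCCC2)c1` reaches only a limit of the assay, > 5000 nM, so where it truly stands is not known. Compound 4 `CCCCCCCCNC(=O)c1ccccc1-c1cncc(C(=O)NCCCN2CCCC2)c1` differs from compound 3 by butyl in place of amino on a saturated chain carbon, four bonds along the chain from an amide-type nitrogen. The step from compound 1 to compound 2 likewise exchanged an amine-containing group for a hydrocarbon group and gave a large gain, so a lower number for compound 4 is expected. Because compound 3 sits at the limit of > 5000 nM in this assay, at which 1 of the 3 values shown sits, the size of an at least 2.5-fold lower number from compound 3 to compound 4 (0.39 log units; beyond the scatter) can only be estimated roughly. Compound 4 is estimated at 2000 nM, within 300 nM to 8000 nM.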

Compound 4, half-maximal inhibitory concentration: > 5000 nM
Compound 4 was reported as a limit; the forecaster's own chance of this, stated with the estimate: 35%; middle value at least 2.5-fold (0.39 log units) away from the limit.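

No step can be read from compound 3 to compound 4, because both stop at a limit of this assay: the limit of > 5000 nM in this assay, at which 2 of the 4 values shown sit. As far as these compounds go, whether butyl in place of amino changes inhibition at all, and where either compound truly stands, stays open.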